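Aryl variation on a thiazolidinone core in HOS-TE85 cells

A few compounds are considered here, and "the series" means these few. Any claim that something is new, unique, unknown or untested is made for them only; others in the source may bear on it.

The measured compounds:
compound 1, `COc1ccc(C)cc1N1C(=O)CSC1c1cccc(C(=O)NCCCCc2ccccc2)c1`, 300 nM
compound 2, `O=C(NCCCCn1cccn1)c1cccc(C2SCC(=O)N2c2ccccn2)c1`, 60.3 nM
compound 3, `COc1ccccc1N1C(=O)CSC1c1cc(C)cc(C(=O)NCCCCc2ccccc2)c1`, 16.2 nM

The three compounds were tested in a functional assay on HOS-TE85 cells (Homo sapiens) for inhibition, read by CCK-8 assay, with a stated time of 72 h; on this read-out lower numbers stand for stronger inhibition and higher numbers for weaker inhibition. Compound 1 stands at the highest number of the three, so on this read-out it is the weakest inhibitor in the set. Compound 2 lies nearest to it, at a lower number that is beyond the scatter, and compound 3 lies furthest, at a number lower still. Compounds 2 and 3 each differ from compound 1 in several places at once, so none of these gaps can be traced to one change.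

Compound 4, `COc1c(F)cccc1N1C(=O)CSC1c1cccc(C(=O)NCCCCc2ccccc2)c1`, differs from compound 1 in one place: 3-fluoro-2-methoxyphenyl in place of 2-methoxy-5-methylphenyl on an amide-type nitrogen in a ring. Among the measured compounds shown here, no measured pair shows this change by itself, so the step from compound 1 to compound 4 has no direct precedent in the data. The expectation is a small step, if any, from compound 1 to compound 4 of a 1.5-fold lower number from compound 1 to compound 4 (0.18 log units; within the scatter), likely within the scatter, leaning toward a lower number. Compound 4 is therefore estimated at 200 nM, in a range from 70 nM to 600 nM.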

Compound 4, half-maximal inhibitory concentration: 26.2 nM
Compound 4: the middle estimate sits 7.6-fold (0.88 log units) above what was measured; the whole stated range lies above it.
By their numbers in this assay, from the lowest: compounds 3 and 4 (each within the scatter of the next); then compound 2; then compound 1.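

Among the compounds shown here, on the amide-type nitrogen of the shared core, the aryl group matters far more than the earlier compounds could show: in this assay, 3-fluoro-2-methoxyphenyl in place of 2-methoxy-5-methylphenyl gives an 11-fold lower number from compound 1 to compound 4 (1.06 log units; beyond the scatter), a large step beyond the scatter. The leaving and entering groups have the same heavy-atom and hydrogen-bond acceptor counts and the same type of aromatic ring, so those counts do not track the change in inhibition in this pair. No measurement on hand accounts for the size of this step.

The swap removes a methyl and adds a fluorine in one move, leaving open which of the two carries the step. Also open, from the compounds shown here alone, is how the same ring would fare with a chloro or an amino group in place of the fluorine.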